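Swapping piperazinyl for methoxyanilino on a shared core

This account rests on a few compounds, and the source may have more. Where it says the series, first, only, none or still open, it means among the compounds named here.

Two measured compounds share one core and were tested for cytotoxicity. Compound 1 `Cc1cc(NCCO)nc(SCc2nc3ccccc3[nH]2)n1` reaches only the limit of a functional assay on MCF7 cells (Homo sapiens) for cytotoxicity, read by MTT assay, with a stated time of 72 h; on this read-out lower numbers stand for stronger inhibition and higher numbers for weaker inhibition; in that assay compound 1 gives > 100000 nM, a limit rather than a number. Compound 2 `Cc1cc(N2CCNCC2)nc(SCc2nc3ccccc3[nH]2)n1`, which carries piperazin-1-yl on an aromatic carbon in place of (2-hydroxyethyl)amino, gives only the limit > 100000 nM. The step that the two limits leave unreadable from compound 1 to compound 2 therefore stays unreadable. Compound 3 `COc1ccccc1Nc1cc(C)nc(SCc2nc3ccccc3[nH]2)n1` brings ((2-methoxyphenyl)amino in place of piperazin-1-yl on an aromatic carbon). Going by the values given here, no measured step bears on this change, as the limit of > 100000 nM in this assay, at which 2 of the 2 values shown sit, shows both values sitting at the limit. Compound 3 is nevertheless expected near 40000 nM, between 5000 nM and 200000 nM, an estimated step of an at least 2.5-fold lower number from compound 2 to compound 3 (0.39 log units; beyond the scatter) that remains very uncertain.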

Compound 3, half-maximal inhibitory concentration: > 100000 nM
Compound 3: no number, only a limit (the forecaster's own chance of this, stated with the estimate: 50%); at least 2.5-fold (0.39 log units) between middle value and limit.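

Going by these compounds alone, compound 3 gives > 100000 nM, a limit and not a number, so no step among compound 1, compound 2 and compound 3 can be read. The compounds shown leave open whether any group at this place on the shared core yields a measurable number in this assay.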